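The compounds below may be only part of what the source reports. "The series", "measured", "known", "first", "only" and "open" are said of these compounds alone.

Measured in a functional assay on NCI/ADR-RES cells (Homo sapiens) for inhibition; a higher number here means a weaker inhibitor of growth, a lower number a stronger inhibitor of growth:
- compound 1 `O=S(=O)(/C=C/c1ccc(C(F)(F)F)cc1F)Cc1ccc(Nc2ncnc3ccc(Br)cc23)cc1`: 85000 nM
- compound 2 `O=S(=O)(/C=C/c1ccc(Cl)cc1Cl)Cc1ccc(Nc2ncnc3cc(Cl)ccc23)cc1`: > 100000 nM (a limit)
- compound 3 `O=S(=O)(/C=C/c1ccc(C(F)(F)F)cc1F)Cc1ccc(Nc2ncnc3cc(Cl)ccc23)cc1`: > 100000 nM (a limit)

Compound 3 is reported only as a limit, > 100000 nM. It shares the limit of > 100000 nM in this assay, at which 2 of the 3 values shown sit, with compound 2, so the numbers offer little to work from.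

Compound 4 `O=S(=O)(/C=C/c1ccc(F)cc1F)Cc1ccc(Nc2ncnc3cc(Cl)ccc23)cc1` keeps the core of compound 3 but carries fluoro in place of trifluoromethyl on an aromatic carbon, (fluoro in place of trifluoromethyl on an aromatic carbon).

For the measured compounds named here, two measured steps bear on this change, though only loosely. The nearest one alters the same aryl group but gives no size: a step that the two limits leave unreadable from compound 2 to compound 3. The other concerns a different group: an at least 1.1-fold higher number from compound 1 to compound 3 (0.07 log units; that floor lies within the scatter). Neither provides a measured size for the new change, so no step beyond the scatter is expected in this assay, and a further report at the limit is quite likely.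

The expected step is an at least 1.1-fold lower number from compound 3 to compound 4 (0.04 log units; that floor lies within the scatter). For compound 4 the estimated value is 90000 nM, with an expected range of 40000 nM to 150000 nM.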

Compound 4, concentration for 50% growth inhibition: > 100000 nM
Compound 4 gave a limit, no number (the forecaster's own chance of this, stated with the estimate: 65%); at least 1.1-fold (0.04 log units) between middle value and limit.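

In this assay compound 4 gives > 100000 nM, which is a limit and not a number. The steps to compound 4 from compound 2 and compound 3, also limits, cannot be read. The compounds shown leave open whether fluoro in place of trifluoromethyl changes growth inhibition at all.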